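This account rests on a few compounds, and the source may have more. Where it says the series, first, only, none or still open, it means among the compounds named here.

Measured so far in a functional assay on HEL cells (Homo sapiens) for cytotoxicity; on this read-out higher numbers stand for lower toxicity in this test and lower numbers for higher toxicity in this test:
compound 1 `CCCCCCCCC#Cc1cc2cn([C@H]3C[C@H](O)[C@@H](CO)O3)c(=O)nc2o1` gives 52000 nM
compound 2 `CCCCCCCCC#Cc1cc2cn([C@@H]3O[C@H](CO)[C@@H](O)[C@H]3O)c(=O)nc2o1` gives 49000 nM

Among the compounds with values here, compound 2 and compound 1 sit together on this read-out: the single step of a 1.1-fold lower number from compound 1 to compound 2 (0.03 log units; within the scatter) is within the scatter, so neither compound can be set above the other.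

Compound 3 `CCCCCCCCC#Cc1cc2cn(C)c(=O)nc2o1` is not yet measured. It differs from compound 2 by methyl in place of 3,4-dihydroxy-5-(hydroxymethyl)oxolan-2-yl on an aromatic nitrogen; the whole five-membered ring with its three hydroxy groups is exchanged for one carbon on the aromatic nitrogen.

Within the data shown here, no measured step bears directly on this change. Among the measured compounds shown here, the only step known, from compound 1 to compound 2, concerns a hydroxy in place of hydrogen on a saturated ring carbon within that ring, and it was within the scatter; it tells nothing about removing the ring altogether. With one pair only, and that pair flat, there is no basis for expecting a shift in this assay in either direction. The expectation is therefore a step of a 1.0-fold higher number from compound 2 to compound 3 (0.01 log units; within the scatter) that stays within the scatter, with a wide range to allow for the size of the change. Compound 3 is estimated at 50000 nM, between 15000 nM and 150000 nM.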

Compound 3, minimum cytotoxic concentration: > 175000 nM
Compound 3 gave a limit, no number (the forecaster's own chance of this, stated with the estimate: 30%); at least 3.5-fold (0.54 log units) between middle value and limit.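

Position: the aromatic nitrogen of the shared core. In this assay, replacing 3,4-dihydroxy-5-(hydroxymethyl)oxolan-2-yl with methyl at this nitrogen gives an at least 3.5-fold higher number from compound 2 to compound 3 (0.55 log units; beyond the scatter), and replacing 4-hydroxy-5-(hydroxymethyl)oxolan-2-yl with methyl gives an at least 3.3-fold higher number from compound 1 to compound 3 (0.52 log units; beyond the scatter). Both steps lie beyond the scatter, so exchanging the whole ring for methyl moves this read-out towards lower toxicity in this test, whereas the single ring hydroxy of the earlier pair, a 1.1-fold lower number from compound 1 to compound 2 (0.03 log units; within the scatter), left compounds 1 and 2 together. The value for compound 3 is a limit of the assay and not a number, so its true distance from the ring-bearing compounds stays undefined: the limit of > 175000 nM in this assay, at which 1 of the 3 values shown sits.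

The compounds shown do not separate the effect of the ring itself from that of its remaining hydroxy and hydroxymethyl groups, a question that an unsubstituted oxolan-2-yl or a hydroxyethyl chain on the same nitrogen would address. As far as these compounds go, the long alkynyl chain is common to all three compounds, so its contribution to this read-out remains open, as does the outcome with a shorter chain or a terminal amine in its place.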